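Tert-butyl repeated on a second core

The source may report more compounds than this note shows. Statements on the series, on what has been measured and on what is new or still open speak of the compounds shown alone.

Three compounds have been measured in a functional assay on PC-3 cells (Homo sapiens) for antiproliferative activity, read by MTT assay, with a stated time of 24 h; a lower number here means a stronger inhibitor, a higher number a weaker inhibitor:

compound 1 `O=C1NC(O)(CCn2cc(-c3ccccc3)nn2)C(OCc2ccccc2)=C1OCc1ccccc1`: > 100000 nM, which is a limit of the assay rather than a number.
compound 2 `CC(C)(C)c1ccc(-c2cn(CCC3(O)NC(=O)C(OCc4ccccc4)=C3OCc3ccccc3)nn2)cc1`: 43000 nM.
compound 3 `COC1=C(OC)C(O)(CCn2cc(-c3ccccc3)nn2)NC1=O`: 35300 nM.

Compound 1 and compound 2 share a core and differ only by tert-butyl in place of hydrogen on an aromatic carbon. This change made an at least 2.3-fold lower number from compound 1 to compound 2 (0.36 log units; beyond the scatter). The step can only be given as a lower bound because compound 1 sits at the limit of > 100000 nM in this assay, at which 1 of the 3 values shown sits. Compound 3 carries a different core; the difference between the two cores is not broken down here. In this assay compound 3 and compound 2 lie within the usual scatter of each other, so no order between them is claimed.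

Compound 4 `COC1=C(OC)C(O)(CCn2cc(-c3ccc(C(C)(C)C)cc3)nn2)NC1=O` is not yet measured. It stands to compound 3 exactly as compound 2 stands to compound 1: the change is tert-butyl in place of hydrogen on an aromatic carbon, the same change at the same place. For the measured compounds named here, the only guide is the one earlier instance, in which compound 2 improved on compound 1 by an at least 2.3-fold lower number from compound 1 to compound 2 (0.36 log units; beyond the scatter). On that basis compound 4 is expected to show a step of a 2.5-fold lower number from compound 3 to compound 4 (0.40 log units; beyond the scatter) in this assay, a modest gain of about the same size as the earlier one. The estimate for compound 4 is 14000 nM, expected to fall between 5000 nM and 35000 nM.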

Compound 4, half-maximal inhibitory concentration: 30400 nM
Beside the measured number, compound 4's estimate is 2.2-fold (0.34 log units) below it; measured number inside the range.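

On the core of compound 3, tert-butyl in place of hydrogen on an aromatic carbon gave a 1.2-fold lower number from compound 3 to compound 4 (0.06 log units; within the scatter) in this assay, so compound 3 and compound 4 cannot be told apart in this assay, and the step seen on the core of compound 1 does not show itself again on this second core. Set side by side, the two instances of the change read as follows: the same change on two cores in this assay, an at least 2.3-fold lower number (0.36 log units; beyond the scatter) from compound 1 to compound 2 and a 1.2-fold lower number (0.06 log units; within the scatter) from compound 3 to compound 4; the limit leaves it open whether they differ. Compound 1 is recorded at > 100000 nM, which is a limit of the assay and not a number, so this pair of steps shows neither that the gain carries over to the core of compound 3 nor that the two cores truly respond differently to the change.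

The compounds shown leave open whether another group at the same place on the aromatic ring, such as a methoxy, a trifluoromethyl or an amine, would give a step beyond the scatter on either core. They also leave open how large the step on the core of compound 1 really is, as one end of it rests on a limit alone.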